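The source may report more compounds than this note shows. Statements on the series, on what has been measured and on what is new or still open speak of the compounds shown alone.

Measured so far in a functional assay on HEp-2 cells (Homo sapiens) for cytotoxicity, read by MTT assay, with a stated time of 72 h, tested at 1.25 ug/mL; on this read-out higher numbers stand for more inhibition of growth at the one concentration tested and lower numbers for less inhibition of growth:
compound 1 `O=C1NC(=S)/C(=C/c2ccc(Cl)cc2)S1` gives 0.92%
compound 2 `O=C1NC(=S)/C(=C/c2ccc(Cl)c(Cl)c2)S1` gives -5.45%
compound 3 `O=C1NC(=S)/C(=C/c2cccc(Br)c2)S1` gives -5.3%

Compound 1 carries the highest number of the three, yet its gaps to compound 3 and to compound 2 are both within the scatter, so the three are not separated. Going by the values given here, the only one-place step measured is the one from compound 1 to compound 2 (a number 6.4 percentage points lower from compound 1 to compound 2 (within the scatter)), and it is the one that bears on the next compound. Compound 4 `O=C1NC(=S)/C(=C/c2ccc(Cl)cc2Cl)S1` differs from compound 1 by chloro in place of hydrogen on an aromatic carbon. Among the compounds with values here, since the single comparable step showed no shift beyond the scatter, no step of meaningful size in this assay is expected for this further chloro either. Compound 4 is therefore estimated at -2%, with a range from -14% to 10%, which would be a step of a number 2.9 percentage points lower from compound 1 to compound 4 (within the scatter).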

Compound 4, percent growth inhibition at one concentration: 6.83%
Compound 4: middle estimate off by 8.8 percentage points, on the low side; the measured number falls inside the stated range.
By their numbers in this assay, from the lowest: compounds 2, 3, 1 and 4 (each within the scatter of the next, the first and the last beyond it).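

In this assay, chloro in place of hydrogen on an aromatic carbon, ortho to a group of 8 heavy atoms and meta to a chloro group, gives a number 5.9 percentage points higher from compound 1 to compound 4 (within the scatter) and so leaves compound 4 not separated from its parent. With a number 6.4 percentage points lower from compound 1 to compound 2 (within the scatter) at a different ring carbon, two placements of this change have now stayed within the scatter. No measurement at hand explains the step.

Open, as far as these compounds go, is whether an amine or a carboxylic acid on this same aromatic carbon would move the number beyond the scatter. Also open, from the compounds shown here alone, is how these compounds would read at concentrations other than the single one tested.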